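The source may report more compounds than this note shows. Statements on the series, on what has been measured and on what is new or still open speak of the compounds shown alone.

Compound 1 `O=C([C@@H]1CCCN(S(=O)(=O)c2ccc(S(=O)(=O)C3CCC3)cc2)C1)N1CCC(F)(F)CC1` gives > 3000 nM in a functional assay on MIA PaCa-2 cells (Homo sapiens) for inhibition, read by MTT assay, with a stated time of 3 days (a higher number here means a weaker inhibitor, a lower number a stronger inhibitor), a limit.
Compound 2 `CC(C)S(=O)(=O)c1ccc(S(=O)(=O)N2CCC[C@@H](C(=O)N3CCC(F)(F)CC3)C2)cc1` gives > 3000 nM in this assay, a limit.
Compound 3 `CCN(CC)S(=O)(=O)c1ccc(S(=O)(=O)N2CCC[C@@H](C(=O)N[C@H]3CC[C@@H](OC)CC3)C2)cc1` gives > 10000 nM in this assay, a limit.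

For the measured compounds named here, compound 3 therefore stands at the limit of > 10000 nM in this assay, at which 1 of the 3 values shown sits, while the other two values sit at the limit of > 3000 nM in this assay, at which 2 of the 3 values shown sit; no compound shows a number. Compound 4 `CCN(CC)S(=O)(=O)c1ccc(S(=O)(=O)N2CCC[C@@H](C(=O)N3CCC(F)(F)CC3)C2)cc1` carries 4,4-difluoropiperidin-1-yl in place of (4-methoxycyclohexyl)amino on a carbonyl carbon. Going by the values given here, the only measured step, a step that the two limits leave unreadable from compound 1 to compound 2, is unreadable and concerns a different part of the molecule. The 4,4-difluoropiperidin-1-yl amide that enters in compound 4 is already present in compound 1, which gives > 3000 nM, a limit. Compound 2, carrying the same amide, gives > 3000 nM, also a limit. Compound 4 is thus expected to remain weak, the expected step being an at least 1.6-fold lower number from compound 3 to compound 4 (0.22 log units; that floor lies within the scatter). Compound 4 is estimated at 6000 nM, with a range from 1500 nM to 30000 nM, and will most likely be reported only as a limit.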

Compound 4, half-maximal inhibitory concentration: > 10000 nM
Compound 4: only a limit was reported; the forecaster's own chance of this, stated with the estimate: 75%; at least 1.6-fold (0.22 log units) between middle value and limit.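

In this assay compound 4 gives > 10000 nM, a limit, and its steps from compound 1, compound 2 and compound 3, all limits too, cannot be read. The compounds shown leave open whether changing either the amide or the sulfonyl group alters inhibition at all.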